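Amide aryl variation on the shared core

The compounds below may be only part of what the source reports. "The series", "measured", "known", "first", "only" and "open" are said of these compounds alone.

Going by the values given here, in a functional assay on SK-BR-3 cells (Homo sapiens) for antiproliferative activity, read by MTT assay, with a stated time of 72 h (on this read-out higher numbers stand for weaker inhibition and lower numbers for stronger inhibition), compound 2 `CCN1CCN(c2cc(C)c3cc(NC(=O)c4cc5ccccc5[nH]4)ccc3n2)CC1` gives 2550 nM, the lowest of the two numbers so far, while compound 1 `CCN1CCN(c2cc(C)c3cc(NC(=O)c4ccccc4OC)ccc3n2)CC1` gives 15700 nM. Among the compounds with values here, the only measured step, a 6.2-fold lower number from compound 1 to compound 2 (0.79 log units; beyond the scatter), is modest yet beyond the scatter. Compound 3 `CCN1CCN(c2cc(C)c3cc(NC(=O)c4ccccc4)ccc3n2)CC1` differs from compound 2 by phenyl in place of 1H-indol-2-yl on a carbonyl carbon. Within the data shown here, that single step is the only guide here, and no direct comparison of phenyl with 2-methoxyphenyl exists. Because of a 6.2-fold lower number from compound 1 to compound 2 (0.79 log units; beyond the scatter), a weaker number is expected for compound 3, a 3.5-fold higher number from compound 2 to compound 3 (0.55 log units; beyond the scatter). Compound 3 is estimated at 9000 nM, with a range from 3000 nM to 25000 nM.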

Compound 3, half-maximal inhibitory concentration: 18400 nM
Beside the measured number, compound 3's estimate is 2.0-fold (0.31 log units) below it; the measured number falls inside the stated range.
By their numbers in this assay, from the lowest: compound 2; then compounds 1 and 3 (each within the scatter of the next).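

On the carbonyl carbon, the step of a 7.2-fold higher number from compound 2 to compound 3 (0.86 log units; beyond the scatter) in this assay shows that the lower number of compound 2 also holds against unsubstituted phenyl. The methoxy group on the aromatic carbon has no readable effect here, since the step of a 1.2-fold higher number from compound 1 to compound 3 (0.07 log units; within the scatter) with hydrogen in its place leaves compound 1 and compound 3 level. Still open, from the compounds shown here alone, is whether the lower number follows the hydrogen-bond donor of 1H-indol-2-yl or its five-membered aromatic ring, and whether an amine or a carboxylic acid on the phenyl would change the read-out. No available evidence bears on the origin of these steps.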